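Branched Versus Straight Chain on Hydroxy-Amide Triazoles

A few compounds are considered here, and "the series" means these few. Any claim that something is new, unique, unknown or untested is made for them only; others in the source may bear on it.

Compound 1 `CC(C)CCc1cn(-c2ccc(O)c(C(=O)N3CCCCC3)c2)nn1` and compound 2 `CCCCCCc1cn(-c2ccc(O)c(C(=O)N3CCCCC3)c2)nn1` share one core and differ only in the chain on the triazole. In a functional assay on RAW264.7 cells (Mus musculus) for inhibition, read by Griess assay, with a stated time of 20 h (a higher number here means a weaker inhibitor, a lower number a stronger inhibitor), compound 1 reaches only a limit of the assay, > 20000 nM. In this assay compound 2 likewise reaches only a limit, > 20000 nM. The change between them is butyl in place of isopropyl on a saturated chain carbon, two bonds along the chain from an aromatic carbon. The resulting step that the two limits leave unreadable from compound 1 to compound 2 cannot be sized because the limit of > 20000 nM in this assay, at which 3 of the 3 values shown sit, covers both ends of it.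

Compound 3 `CC(C)CCc1cn(-c2ccc(C(=O)N3CCCCC3)c(O)c2)nn1` is made of the same atoms as compound 1, joined differently; the difference between the two cores is not broken down here. In this assay compound 3 also gives only a limit, > 20000 nM.

Compound 4 `CCCCCCc1cn(-c2ccc(C(=O)N3CCCCC3)c(O)c2)nn1` has not yet been measured. It differs from compound 3 by butyl in place of isopropyl on a saturated chain carbon, two bonds along the chain from an aromatic carbon, the same change as from compound 1 to compound 2, at the same place. The step is expected to be a step that the limit leaves unreadable from compound 3 to compound 4 because a step that the two limits leave unreadable from compound 1 to compound 2 showed no readable movement. Compound 4 is therefore estimated at 30000 nM, most likely once more only a limit, with an expected range from 12000 nM to 100000 nM.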

Compound 4, half-maximal inhibitory concentration: > 20000 nM
Compound 4 ended at the assay's limit; the forecaster's own chance of this, stated with the estimate: 85%; the middle value lies beyond the limit too.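

No new step can be read from compound 3 to compound 4, because both stop at the same limit, as do compound 1 and compound 2: the limit of > 20000 nM in this assay, at which 4 of the 4 values shown sit.

The compounds shown leave open whether changing the chain or the core has any effect on potency in this assay since none of them gives a readable value.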